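Adding a hydroxy group to the phenyl compound

The source may hold more compounds than are shown below. What is called first, only, known or untested is meant among the compounds shown, and "the series" means these compounds.

Values in an ADME assay on RAW264.7 cells (Mus musculus) for cytotoxicity, read by MTT assay, with a stated time of 24 h; a lower number here means that less compound is tolerated, a higher number that more compound is tolerated:
compound 1 `CC/C=C\C[C@H]1C(=O)C=C[C@H]1CC(=O)OCCCC` gives 31 uM
compound 2 `CC/C=C\C[C@H]1C(=O)C=C[C@H]1CC(=O)OCCCCC` gives 37 uM
compound 3 `CC/C=C\C[C@H]1C(=O)C=C[C@H]1CC(=O)Oc1ccccc1` gives 158 uM

Compound 3 stands highest of the three, and its gaps to the other two lie beyond the scatter. Phenyl in place of butyl gave a 5.1-fold higher number from compound 1 to compound 3 (0.71 log units; beyond the scatter), and phenyl in place of pentyl gave a 4.3-fold higher number from compound 2 to compound 3 (0.63 log units; beyond the scatter), both modest steps. Methyl in place of hydrogen on the saturated chain gave only a 1.2-fold higher number from compound 1 to compound 2 (0.08 log units; within the scatter) on the same scale.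

Compound 4 `CC/C=C\C[C@H]1C(=O)C=C[C@H]1CC(=O)Oc1ccc(O)cc1` carries hydroxy in place of hydrogen on an aromatic carbon, para to a large group (hydroxy in place of hydrogen on an aromatic carbon), so phenyl becomes 4-hydroxyphenyl. Among the compounds with values here, no measured step touches the aromatic ring, so the evidence is indirect. Within the data shown here, the two modest steps exchanged a whole group, while the one step that added a single small group, a 1.2-fold higher number from compound 1 to compound 2 (0.08 log units; within the scatter), stayed within the scatter. On that slim basis, the starting point is compound 3 at 158 uM in this assay. As far as these compounds go, compound 4 is expected to stay within the scatter of that level, though the direction remains open. The expected step is a 1.1-fold lower number from compound 3 to compound 4 (0.05 log units; within the scatter), a small one. For compound 4 the estimated value is 140 uM, with an expected range from 60 uM to 300 uM, kept wide for want of direct evidence.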

Compound 4, half-maximal toxic concentration: 49 uM
The estimate for compound 4 lay 2.9-fold (0.46 log units) above the measured number; measured number outside the range, below it.
By their numbers in this assay, from the lowest: compounds 1, 2 and 4 (each within the scatter of the next); then compound 3.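

Hydroxy in place of hydrogen on an aromatic carbon, para to a large group, gave a 3.2-fold lower number from compound 3 to compound 4 (0.51 log units; beyond the scatter) in this assay, so this position of the ring responds to a single added heavy atom, whereas the one earlier small change, on the saturated chain, gave only a 1.2-fold higher number from compound 1 to compound 2 (0.08 log units; within the scatter) on the same scale. The gain that came with phenyl did not carry over to 4-hydroxyphenyl: 4-hydroxyphenyl in place of pentyl gave a 1.3-fold higher number from compound 2 to compound 4 (0.12 log units; within the scatter) and 4-hydroxyphenyl in place of butyl gave a 1.6-fold higher number from compound 1 to compound 4 (0.20 log units; within the scatter) and thus, unlike phenyl, 4-hydroxyphenyl stands within the scatter of both chains. Nothing available explains the lower number at this position.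

The compounds shown leave open whether a methoxy group, an amine or a carboxylic acid on the same aromatic carbon would lower the number as hydroxy does, and whether hydroxy on another carbon of the ring would do the same. They also leave open whether a hydroxy group at the end of the butyl or pentyl chain would change the number at all.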